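The compounds below may be only part of what the source reports. "The series", "measured", "known", "first", "only" and "open" are said of these compounds alone.

Measured compounds:
- Compound 1 `Cc1ccc(OCC(=O)N(Cc2cccs2)C2COC2)cc1`: 23000 nM
- Compound 2 `Cc1ccc(OCC(=O)N(Cc2cccs2)C(C)(C)C)cc1`: 11000 nM
- Compound 3 `Cc1ccc(OCC(=O)N(Cc2cccs2)c2c[nH]nc2C)cc1`: 0.4 nM

In an assay on HEK293 cells for agonist activity at transient receptor potential cation channel subfamily M member 8 (Homo sapiens), read by fluorescence and calcium flux, with a stated time of 15 min (a lower number here means that less compound is needed, a higher number that more compound is needed for the effect), compound 3 gives 0.4 nM, the lowest number among the three measured compounds and far apart from the other two. Compound 1, with an oxetan-3-yl group on the amide-type nitrogen, gives 23000 nM, and compound 2, with a tert-butyl group in that place, gives 11000 nM.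

Compound 4 `Cc1ccc(OCC(=O)N(Cc2cccs2)c2ccon2)cc1` has not yet been measured. It differs from compound 3 in one place: 1,2-oxazol-3-yl in place of 3-methyl-1H-pyrazol-4-yl on an amide-type nitrogen. One five-membered aromatic ring is thus exchanged for another, but the hydrogen-bond donor is lost and the methyl group is gone.

Within the data shown here, two measured steps bear on this. The change from oxetan-3-yl to the pyrazole gave a 58000-fold lower number from compound 1 to compound 3 (4.76 log units; beyond the scatter), and from tert-butyl to the pyrazole a 28000-fold lower number from compound 2 to compound 3 (4.44 log units; beyond the scatter). Both show that what sits on this nitrogen decides almost everything in this assay, and that the 3-methyl-1H-pyrazol-4-yl group is the single best choice seen so far. Compound 4 keeps an aromatic ring, so a collapse to the level of compound 1 or compound 2 is not expected, but some loss is expected. The estimated step is a 100-fold higher number from compound 3 to compound 4 (2.00 log units; beyond the scatter). Compound 4 is therefore expected to give about 40 nM, with a likely range from 3 nM to 600 nM.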

Compound 4, half-maximal effective concentration: 2 nM
Compound 4: the middle estimate sits 20-fold (1.30 log units) above what was measured, outside the stated range (below it).
By their numbers in this assay, from the lowest: compound 3; then compound 4; then compound 2; then compound 1.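

In this assay, among these compounds, replacing the 3-methyl-1H-pyrazol-4-yl group with 1,2-oxazol-3-yl gives a 5.0-fold higher number from compound 3 to compound 4 (0.70 log units; beyond the scatter), so the pyrazole still has the lower number, but the cost is small beside the earlier steps on this amide-type nitrogen. Compound 4 keeps most of the pyrazole's advantage over the non-aromatic groups, with a 5500-fold lower number from compound 2 to compound 4 (3.74 log units; beyond the scatter) and a 12000-fold lower number from compound 1 to compound 4 (4.06 log units; beyond the scatter), which shows that the hydrogen-bond donor and the methyl group of compound 3 are not needed for a low number here and that the pyrazole is not the only ring that works at this position. Nothing measured explains why these two rings lie so close together or so far from the tert-butyl and oxetan-3-yl compounds.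

As far as these compounds go, the donor and the methyl group leave together in this change, so their separate shares of the step remain unknown, and a pyrazole without the methyl group could help to separate them. From the compounds shown here alone, it also remains open whether a five-membered aromatic ring matters as such, or whether a six-membered ring such as phenyl or pyridine would also give a low number.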